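A few compounds are considered here, and "the series" means these few. Any claim that something is new, unique, unknown or untested is made for them only; others in the source may bear on it.

Of the compounds shown here, three have been measured in an ADME assay (Canis lupus familiaris, strain Beagle) for metabolic stability; a higher number here means that the compound lasts longer, a lower number that the compound disappears faster. Compound 1 `CCn1c(-c2cnc(C)nc2)nc2c(O[C@H]3CCN(C(=O)C4CC4)C3)ncnc21` gives 1.3 h. Compound 2 `CCC(=O)N1CC[C@H](Oc2ncnc3c2nc(-c2cnc(C)nc2)n3CC)C1` gives 3.9 h, the highest of the three numbers. Compound 3 `CCn1c(-c2ccc(C(F)(F)F)nc2)nc2c(O[C@H]3CCN(C(=O)N4CC(OC)C4)C3)ncnc21` gives 0.7 h, the lowest of the three, and it differs from compound 2 in more than one place, so its value is read on its own. Going by the values given here, compound 1 and compound 2 differ in a single place, and the step between them, a 3.0-fold higher number from compound 1 to compound 2 (0.48 log units; beyond the scatter), is the one comparison that reaches beyond the usual scatter of this assay.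

Compound 4 `CCn1c(-c2cnc(C)nc2)nc2c(O[C@H]3CCN(C(=O)C4CCC4)C3)ncnc21` has not yet been measured. It differs from compound 2 in one place: cyclobutyl in place of ethyl on a carbonyl carbon. Among the compounds with values here, the only measured step that touches the same carbonyl carbon is the one from compound 1 to compound 2, where a ring left and an open chain entered and the number rose. Compound 4 reverses that direction, a ring entering where the open chain stood, with one more carbon in the ring than compound 1 carries. From that single step a drop is expected, roughly undoing the gain seen for compound 2, so the value of compound 4 is expected to land near that of compound 1 as the step of a 3.3-fold lower number from compound 2 to compound 4 (0.51 log units; beyond the scatter). Compound 4 is therefore estimated at 1.2 h, with a likely range from 0.5 h to 3 h.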

Compound 4, half-life: 1.1 h
The estimate for compound 4 lay 1.1-fold (0.04 log units) above the measured number, and the stated range covers the measured number.
By their numbers in this assay, from the lowest: compounds 3, 4 and 1 (each within the scatter of the next); then compound 2.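

In this assay, a second ring now stands on this carbonyl carbon, and cyclobutyl in place of ethyl gives a 3.5-fold lower number from compound 2 to compound 4 (0.55 log units; beyond the scatter), so the drop seen with cyclopropyl is not unique to that one ring. Changing one ring for the other gives a 1.2-fold lower number from compound 1 to compound 4 (0.07 log units; within the scatter), which means that the larger ring makes no readable difference here. Among the one-place changes at this carbonyl carbon, the open-chain propanoyl group of compound 2 therefore stands apart from both ring-bearing partners, rather than the number following ring size.

Still open, going by these compounds, is whether this holds beyond these three groups: a longer open chain such as butanoyl, a branched chain such as isobutyryl or a larger ring such as cyclopentyl could show whether the open chain itself matters or only the propanoyl group does. Nothing available explains why the open chain and the two rings part in this way.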